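A few compounds are considered here, and "the series" means these few. Any claim that something is new, unique, unknown or untested is made for them only; others in the source may bear on it.

Measured compounds:
Compound 1, `Cc1nc(-c2ccccc2)c(C(=O)N2CCN(c3cccc(C(N)=O)c3)CC2)o1`: 71 nM
Compound 2, `COc1cc(OC)cc(N2CCN(C(=O)c3oc(C)nc3-c3ccccc3F)CC2)c1`: 10.3 nM
Compound 3, `COc1cccc(-c2nc(C)oc2C(=O)N2CCN(c3cccc(Cl)c3)CC2)c1`: "not active" (no number reported)

In a functional assay on HL-60 cells (Homo sapiens) for inhibition, read by MTT assay, with a stated time of 72 h (a lower number here means a stronger inhibitor, a higher number a weaker inhibitor), compound 1 gives 71 nM, the highest of the two numbers reported. Its nearest neighbour is compound 2, which in this assay gives 10.3 nM, a gap that lies beyond the usual scatter. Compound 3 is reported in this assay only as "not active" (no number reported), without a number. Compound 1 and compound 2 differ from each other in more than one place, so no single step between them is shown.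

The compound that follows, compound 4, `Cc1nc(-c2ccccc2)c(C(=O)N2CCN(c3ccc(C)c(C)c3)CC2)o1`, has not been measured. It differs from compound 1 in one place: 3,4-dimethylphenyl in place of 3-carbamoylphenyl on an amine nitrogen in a ring. Within the data shown here, no step between measured compounds is available for this change. On the evidence of compound 1 alone, with its 71 nM, a shift in either direction is possible, and a modest move toward a weaker inhibitor, within or just beyond the scatter, is expected as a 1.5-fold higher number from compound 1 to compound 4 (0.19 log units; within the scatter). Compound 4 is therefore estimated at 110 nM, with a range from 25 nM to 450 nM.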

Compound 4, half-maximal inhibitory concentration: 43 nM
For compound 4 the middle estimate is 2.6-fold (0.41 log units) above the measured one; measured number inside the range.
By their numbers in this assay, from the lowest: compound 2; then compounds 4 and 1 (each within the scatter of the next).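

In this assay, placing 3,4-dimethylphenyl where 3-carbamoylphenyl stood on the ring amine nitrogen gives a 1.7-fold lower number from compound 1 to compound 4 (0.22 log units; within the scatter) and leaves the two compounds indistinguishable. The group that leaves carries a hydrogen-bond donor and a hydrogen-bond acceptor, and the group that enters carries neither, so for this pair those features of the aromatic substituent do not separate the results. An all-carbon substituent can therefore stand at this position with a number in the same range as the carbamoyl compound, although nothing available accounts for this result.

As far as these compounds go, whether a carboxylic acid or a dimethylamino group on this phenyl ring would give a similar number remains open. So does the question of what either methyl group of 3,4-dimethylphenyl contributes alone.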